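The compounds below may be only part of what the source reports. "The series", "measured", "known", "first", "only" and "open" are said of these compounds alone.

Compound 1 `CC(C)(C)n1nc(Cc2cccc(Br)c2)c2c(N)ncnc21`: 0.05 h
Compound 2 `CC(C)n1nc(Cc2cccc(Cl)c2Cl)c2c(N)ncnc21`: 0.117 h

In an ADME assay on microsomes from liver (Rattus norvegicus) for metabolic stability, read by LC-MS (a lower number here means that the compound disappears faster, a higher number that the compound lasts longer), compound 2 has the higher of the two numbers, and its gap to compound 1 lies beyond the scatter. Compound 3 `CC(C)n1nc(C(F)c2cccc(Cl)c2Cl)c2c(N)ncnc21` differs from compound 2 by fluoro in place of hydrogen on a saturated chain carbon bound to two aromatic carbons. Going by the values given here, no measured pair shows this change, so the expectation is tentative. A small rise in this assay is expected, within the scatter. The estimated step is a 1.5-fold higher number from compound 2 to compound 3 (0.19 log units; within the scatter). For compound 3, the expected half-life is 0.18 h, with an estimated range of 0.07 h to 0.45 h.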

Compound 3, half-life: 0.215 h
Compound 3: middle estimate off by 1.2-fold (0.08 log units), on the low side, and the stated range covers the measured number.
By their numbers in this assay, from the lowest: compound 1; then compounds 2 and 3 (each within the scatter of the next).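

Fluoro in place of hydrogen on a saturated chain carbon bound to two aromatic carbons now has one measured pair: in this assay the step is a 1.8-fold higher number from compound 2 to compound 3 (0.26 log units; within the scatter), which leaves the two half-lives within the scatter of each other. This single pair therefore does not separate the change from no change in this read-out. Nothing measured here bears on a cause for the step.

Going by these compounds, whether a methyl or a hydroxyl on that same carbon would give a step beyond the scatter stays open. One pair also leaves open whether the fluoro step would repeat on other members of the series.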